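Indole nitrogen substituent and rat prostate reductase inhibition

The compounds below may be only part of what the source reports. "The series", "measured", "known", "first", "only" and "open" are said of these compounds alone.

Measured so far:
compound 1 `CCCCCn1ccc2cc(/C(C)=C/C(=O)Nc3ccccc3OCCCC(=O)O)ccc21`: 23 nM
compound 2 `CCCC(CC)n1ccc2cc(/C(C)=C/C(=O)Nc3ccccc3OCCCC(=O)O)ccc21`: 9.3 nM

In an assay on Prostate gland for inhibition of steroid 5-alpha-reductase (Rattus norvegicus) (on this read-out higher numbers stand for weaker inhibition and lower numbers for stronger inhibition), compound 2 gives the lowest of the two numbers; its nearest neighbour is compound 1 with 23 nM, and the step of a 2.5-fold lower number from compound 1 to compound 2 (0.39 log units; beyond the scatter) lies beyond the scatter. Compound 3 `C/C(=C\C(=O)Nc1ccccc1OCCCC(=O)O)c1ccc2c(ccn2Cc2ccc(F)cc2)c1` carries 4-fluorobenzyl in place of 1-ethylbutyl on an aromatic nitrogen. Among the measured compounds shown here, the only measured step at this aromatic nitrogen, a 2.5-fold lower number from compound 1 to compound 2 (0.39 log units; beyond the scatter), exchanged one chain for another and says nothing about an aromatic ring entering there, so it bears on the new step only by place, not by kind. No direction can be read from it. The estimated step is a 1.6-fold higher number from compound 2 to compound 3 (0.21 log units; within the scatter), although a step beyond the scatter in either direction cannot be ruled out. The estimate for compound 3 is therefore kept near the measured value of its nearest neighbour, at an expected 15 nM with a wide range from 4 nM to 60 nM.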

Compound 3, half-maximal inhibitory concentration: 97 nM
Beside the measured number, compound 3's estimate is 6.5-fold (0.81 log units) below it; measured number outside the range, above it.
By their numbers in this assay, from the lowest: compound 2; then compound 1; then compound 3.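

The steps of a 10-fold higher number from compound 2 to compound 3 (1.02 log units; beyond the scatter) and a 4.2-fold higher number from compound 1 to compound 3 (0.63 log units; beyond the scatter) in this assay show that this aromatic nitrogen does not accept every group alike. Among the compounds shown here, the only ring-bearing group here, 4-fluorobenzyl, gives a higher number than either open chain, pentyl or 1-ethylbutyl. Nothing available explains this difference.

From the compounds shown here alone, whether the higher number goes with the aromatic ring or with its fluorine stays open, and plain benzyl and cyclohexylmethyl at this nitrogen would separate the two. Going by these compounds, how far chain branching can go beyond 1-ethylbutyl also stays open.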